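The source may report more compounds than this note shows. Statements on the series, on what has been measured and on what is new or still open speak of the compounds shown alone.

Measured in a physicochemical assay for solubility, in phosphate buffer, with a stated time of 24 h, at pH 7.4, tested at 100 uM; a higher number here means a more soluble compound, a lower number a less soluble compound:
Compound 1 `O=C(NCc1ccc(S(=O)(=O)c2ccccc2)cc1)NCc1cccnc1`: 10000 nM
Compound 2 `O=C(NCc1ccc(S(=O)(=O)c2ccccc2)cc1)N1Cc2ccncc2C1`: 115000 nM
Compound 3 `O=C(NCc1ccc(S(=O)(=O)c2cccc(C(F)(F)F)c2)cc1)N1Cc2ccncc2C1`: 10000 nM

Compound 3 stands level with compound 1 at the low end of these three, well under compound 2. Compound 4 `O=C(NCc1ccc(S(=O)(=O)c2cncc(C(F)(F)F)c2)cc1)N1Cc2ccncc2C1` differs from compound 3 in one place: 5-(trifluoromethyl)pyridin-3-yl in place of 3-(trifluoromethyl)phenyl on a sulfonyl sulfur. For the measured compounds named here, no measured step makes this exchange. The closest is a 12-fold lower number from compound 2 to compound 3 (1.06 log units; beyond the scatter), a large step made on the same aromatic ring. The other, a 12-fold higher number from compound 1 to compound 2 (1.06 log units; beyond the scatter), is equally large but was made elsewhere, on a carbonyl carbon. A moderate upward step in this assay is therefore expected, smaller than either, though with little direct support. The expected change is a 3.0-fold higher number from compound 3 to compound 4 (0.48 log units; beyond the scatter). For compound 4 the estimated value is 30000 nM, with an expected range of 12000 nM to 80000 nM.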

Compound 4, solubility: 83000 nM
Beside the measured number, compound 4's estimate is 2.8-fold (0.44 log units) below it; the whole stated range lies below it.
By their numbers in this assay, from the lowest: compounds 1 and 3 (each within the scatter of the next); then compounds 4 and 2 (each within the scatter of the next).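

In this assay, for the compounds shown here, 5-(trifluoromethyl)pyridin-3-yl in place of 3-(trifluoromethyl)phenyl on the sulfonyl sulfur gives an 8.3-fold higher number from compound 3 to compound 4 (0.92 log units; beyond the scatter), the first change at this position to go upward. Against the unsubstituted phenyl, the same group gives a 1.4-fold lower number from compound 2 to compound 4 (0.14 log units; within the scatter), which lies within the scatter, so the pyridine ring carries trifluoromethyl with no loss that can be read. No evidence at hand accounts for this difference between the two rings. Still open, from the compounds shown here alone, is whether a nitrile or a methoxy group in place of trifluoromethyl would behave the same way on either ring.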